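Moving a hydroxyl on the aryl group: compound 3 to compound 4

A few compounds are considered here, and "the series" means these few. Any claim that something is new, unique, unknown or untested is made for them only; others in the source may bear on it.

Measured compounds:
compound 1 `Cc1cc(-c2cccc(F)c2)c2ncc(CSCCc3ccccc3)n2c1`, 20 ug/mL
compound 2 `Cc1cc(-c2ccc(O)cc2)c2ncc(CSCCc3ccccc3)n2c1`, 20 ug/mL
compound 3 `Cc1cc(-c2ccc(O)cc2)cn2c(CSCCc3ccccc3)cnc12`, >= 100 ug/mL

In an ADME assay on HEL cells (Homo sapiens) for cytotoxicity, with a stated time of 3 days (on this read-out higher numbers stand for lower toxicity in this test and lower numbers for higher toxicity in this test), compound 1 gives 20 ug/mL. Compound 2 gives 20 ug/mL, and the step of no change at the digits printed from compound 1 to compound 2 (within the scatter) shows no change within the scatter. For compound 3 the read-out is a limit, not a number: the limit of >= 100 ug/mL in this assay, at which 1 of the 3 values shown sits. Compound 4 `Cc1cc(-c2cccc(O)c2)cn2c(CSCCc3ccccc3)cnc12` differs from compound 3 only in this: 3-hydroxyphenyl in place of 4-hydroxyphenyl on an aromatic carbon. Among the compounds with values here, the one measured step concerns a different aryl change on a different core, so it offers little guidance here. Given that compound 3 sits at a limit, the step from compound 3 to compound 4 is expected to be small, a number no higher from compound 3 to compound 4 (the limit leaves the size open). Compound 4 is therefore estimated at 100 ug/mL, within a range of 40 ug/mL to 200 ug/mL.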

Compound 4, minimum cytotoxic concentration: 20 ug/mL
Beside the measured number, compound 4's estimate is 5.0-fold (0.70 log units) above it; the whole stated range lies above it.
By their numbers in this assay, from the lowest: compounds 1, 2 and 4 (each within the scatter of the next). At a limit, above all of these: compound 3.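

In this assay, 3-hydroxyphenyl in place of 4-hydroxyphenyl gives an at least 5.0-fold lower number from compound 3 to compound 4 (0.69 log units; beyond the scatter). On this core, then, the place of the hydroxyl on the aryl group alone changes the read-out, though the two groups have the same atoms, something the earlier step on another core could not show. How large the step is stays unsettled, as compound 3 carries a limit and not a number: the limit of >= 100 ug/mL in this assay, at which 1 of the 4 values shown sits.

Going by these compounds, whether an amine or a carboxylic acid on this aryl ring would read like compound 3 or like compound 4 stays open. So does whether moving the hydroxyl on the core of compound 2 would change the read-out as well.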